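Phenoxy to Methylsulfonyl: Expected Cytotoxicity of Compound 4

The compounds below may be only part of what the source reports. "The series", "measured", "known", "first", "only" and "open" are said of these compounds alone.

Three compounds sharing one core were tested in an ADME assay on BJ cells (Homo sapiens) for cytotoxicity, read by CellTiter-Glo and resazurin assay, with a stated time of 72 h (a higher number here means that more compound is needed for the effect, a lower number that less compound is needed), each differing only in the group on one aromatic carbon. Compound 1 `CC(C)N(Cc1cccc(OCCCCCC(=O)O)c1)C(=O)c1ccc(-c2cccc(N(C)C)c2)cc1` carries a dimethylamino group; in this assay compound 1 reaches only a limit of the assay, > 26000 nM. Compound 2 `CC(=O)Nc1cccc(-c2ccc(C(=O)N(Cc3cccc(OCCCCCC(=O)O)c3)C(C)C)cc2)c1` carries an acetamido group there, and in this assay compound 2 likewise reaches only a limit, > 26000 nM. Compound 3 `CC(C)N(Cc1cccc(OCCCCCC(=O)O)c1)C(=O)c1ccc(-c2cccc(Oc3ccccc3)c2)cc1` carries a phenoxy group, and in this assay compound 3 also gives only a limit, > 18700 nM. Since every value is a limit, the steps a step that the two limits leave unreadable from compound 1 to compound 2, a step that the two limits leave unreadable from compound 1 to compound 3 and a step that the two limits leave unreadable from compound 2 to compound 3 cannot be sized. Compound 3 stands at the limit of > 18700 nM in this assay, at which 1 of the 3 values shown sits, while the other two sit at the limit of > 26000 nM in this assay, at which 2 of the 3 values shown sit; no ordering among them can be read.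

Compound 4 `CC(C)N(Cc1cccc(OCCCCCC(=O)O)c1)C(=O)c1ccc(-c2cccc(S(C)(=O)=O)c2)cc1` differs from compound 3 in one place: methylsulfonyl in place of phenoxy on an aromatic carbon. The three measured steps all touch this same position, yet none yields a readable size, so they offer no direction to carry over. Given that all three measured compounds sit at a limit, compound 4 is expected to sit at one too, with an estimated 30000 nM, ranging from 15000 nM to 80000 nM. The implied step that the limit leaves unreadable from compound 3 to compound 4 is expected to stay within the scatter.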

Compound 4, half-maximal effective concentration: > 26000 nM
Compound 4 gave a limit, no number; the forecaster's own chance of this, stated with the estimate: 85%; the middle value lies beyond the limit too.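

In this assay compound 4 gives only a limit, > 26000 nM. With every value a limit, the steps from compound 1, compound 2 and compound 3 to compound 4 cannot be read. The compounds shown leave open at what concentration any of them reaches the half-maximal effect, and whether these four groups differ at all.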